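This account rests on a few compounds, and the source may have more. Where it says the series, first, only, none or still open, it means among the compounds named here.

Measured compounds:
compound 1 `COc1ccccc1N1CCN(CCCNc2ncccc2C(=O)NC(C)(C)C)CC1` with 1.26 nM
compound 2 `COc1ccccc1N1CCN(CCCNc2cncnc2C(=O)N(C)C)CC1` with 3.98 nM
compound 3 `CCOc1ccccc1N1CCN(CCCNc2ncccc2C(=O)N(C)C)CC1` with 0.501 nM

In a functional assay for antagonist activity at Alpha-1A adrenergic receptor (Oryctolagus cuniculus) (a higher number here means weaker binding, a lower number tighter binding), compound 3 stands at the lowest number of the three, that is, it binds the tightest; its gap to compound 1 is the smaller one and its gap to compound 2 the larger, and both gaps lie beyond the usual scatter of this assay. Compound 4 `CN(C)C(=O)c1cccnc1NCCCN1CCN(c2ccccc2OCC2CC2)CC1` has not yet been measured in this assay. It differs from compound 3 in one place: cyclopropyl in place of methyl on a saturated chain carbon bound to an oxygen on an aromatic ring. Put more simply, the ethoxy group on the aromatic ring of compound 3 becomes a cyclopropylmethoxy group in compound 4. Within the data shown here, no pair of measured compounds differs only in the size of this alkoxy group, so the data give no direct guide to the size of this step. The change is modest, and no movement beyond the scatter is expected in this assay. Compound 4 is therefore estimated at 0.6 nM, within a range of 0.2 nM to 1.8 nM, which means an expected step of a 1.2-fold higher number from compound 3 to compound 4 (0.08 log units; within the scatter).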

Compound 4, dissociation constant: 0.159 nM
Compound 4: the middle estimate sits 3.8-fold (0.58 log units) above what was measured; the whole stated range lies above it.
By their numbers in this assay, from the lowest: compound 4; then compound 3; then compound 1; then compound 2.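

In this assay, among these compounds, the change from ethoxy to cyclopropylmethoxy gives a 3.2-fold lower number from compound 3 to compound 4 (0.50 log units; beyond the scatter) and thus offers the first direct reading of this place on the aromatic ring, since no earlier pair of compounds differed only there. It shows that this place tolerates a larger alkoxy group carrying a three-membered ring, and that the change here lowers the number rather than leaving it unchanged or raising it. No measurement available here explains the lower number.

From the compounds shown here alone, a single step cannot separate the effect of the ring from that of the larger group, so it remains open whether an isobutoxy group, a longer chain such as butoxy, or a benzyloxy group would give a similar result. Going by these compounds, it also remains open whether cyclopropylmethoxy would lower the number on the cores of compound 1 and compound 2.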